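The source may report more compounds than this note shows. Statements on the series, on what has been measured and on what is new or still open speak of the compounds shown alone.

Going by the values given here, in a functional assay on K562 cells (Homo sapiens) for inhibition, read by sulforhodamine B assay, with a stated time of 48 h (on this read-out higher numbers stand for weaker inhibition of growth and lower numbers for stronger inhibition of growth), compound 1 (`O=C(Cc1csc2nc(-c3ccc(Br)cc3)cn12)N/N=C/c1ccccc1O`) gives 37.2 nM, while compound 2 (`O=C(Cc1csc2nc(-c3ccc(Br)cc3)cn12)N/N=C/c1ccc(O)cc1`) gives 1820 nM, the higher of the two numbers so far. Compound 3 (`COc1cccc(OC)c1/C=N/NC(=O)Cc1csc2nc(-c3ccc(Br)cc3)cn12`) changes compound 2 at one place: 2,6-dimethoxyphenyl in place of 4-hydroxyphenyl on a carbon with a double bond to nitrogen. Among the compounds with values here, the only measured step at this place is large: a 49-fold higher number from compound 1 to compound 2 (1.69 log units; beyond the scatter). As far as these compounds go, that step shows that changes here can matter greatly in this assay, but the 2,6-dimethoxyphenyl group itself is untested, so it offers only a loose guide. The estimated step is a 4.6-fold lower number from compound 2 to compound 3 (0.66 log units; beyond the scatter), a moderate move towards a lower number. For compound 3, the expected value is 400 nM, with an estimated range from 80 nM to 2000 nM.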

Compound 3, concentration for 50% growth inhibition: 2950 nM
For compound 3 the middle estimate is 7.4-fold (0.87 log units) below the measured one; measured number outside the range, above it.
By their numbers in this assay, from the lowest: compound 1; then compounds 2 and 3 (each within the scatter of the next).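

In this assay, a 1.6-fold higher number from compound 2 to compound 3 (0.21 log units; within the scatter), so replacing 4-hydroxyphenyl with 2,6-dimethoxyphenyl gives no change that can be told from the scatter. By contrast, a 79-fold higher number from compound 1 to compound 3 (1.90 log units; beyond the scatter), so a second group at this place also falls far short of the 2-hydroxyphenyl of compound 1. No measurement at hand explains these differences. The compounds shown leave open whether an amine or a single methoxy group in place of the hydroxyl of compound 1 would keep its low number.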